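Working notes: replacing butylamino in compound 3

The source may hold more compounds than are shown below. What is called first, only, known or untested is meant among the compounds shown, and "the series" means these compounds.

Values in a functional assay on L02 cells (Homo sapiens) for inhibition, read by Griess assay, with stated times of 1 h and 24 h; a higher number here means a weaker inhibitor, a lower number a stronger inhibitor:
- compound 1 `CCCc1nn(C)c2c(NC(C)C)nc(/C=C/c3nc(C)c(C)nc3C)nc12`: 342000 nM
- compound 2 `CCCc1nn(C)c2c(NC(C)C)nc(/C=C/c3cccnc3)nc12`: 574000 nM
- compound 3 `CCCCNc1nc(/C=C/c2ccccc2)nc2ccsc12`: > 1000000 nM (a limit, not a number)
- compound 4 `CN(c1ccccc1)c1nc(/C=C/c2ccccc2)nc2ccsc12`: not yet measured

Compound 3 rests at the limit of > 1000000 nM in this assay, at which 1 of the 3 values shown sits. Its place in this assay is therefore known only as a limit. The change to compound 4 is methyl(phenyl)amino in place of butylamino on an aromatic carbon, with methyl(phenyl)amino in place of butylamino on an aromatic carbon. Within the data shown here, the only measured step, a 1.7-fold higher number from compound 1 to compound 2 (0.22 log units; within the scatter), concerns a different group, the pyridin-3-yl exchange on the double-bonded chain, so it bears on this change only weakly. The estimated step is an at least 1.1-fold lower number from compound 3 to compound 4 (0.04 log units; that floor lies within the scatter), and none beyond the scatter is expected. For compound 4 the expected value is 900000 nM, with an estimated range of 350000 nM to 2000000 nM.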

Compound 4, half-maximal inhibitory concentration: > 1000000 nM
Compound 4 ended at the assay's limit; the forecaster's own chance of this, stated with the estimate: 55%; middle value at least 1.1-fold (0.04 log units) away from the limit.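

Compound 3 and compound 4 both stand at a limit rather than a number in this assay, so no step between them can be read: the limit of > 1000000 nM in this assay, at which 2 of the 4 values shown sit.

Going by these compounds, whether methyl(phenyl)amino in place of butylamino on this core alters inhibition at all remains open.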